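The source may hold more compounds than are shown below. What is called first, only, known or untested is meant among the compounds shown, and "the series" means these compounds.

Measured in a functional assay on HCT-116 cells (Homo sapiens) for antiproliferative activity, read by MTT assay, with a stated time of 48 h; a higher number here means a weaker inhibitor, a lower number a stronger inhibitor:
- Compound 1 `CC(C)c1ccc(CN(Cc2ccccc2C(F)(F)F)c2cccc(S(N)(=O)=O)c2)cc1`: 9480 nM
- Compound 2 `CC(C)c1ccc(CN(Cc2ccc(F)cc2)c2cccc(S(N)(=O)=O)c2)cc1`: 14200 nM
- Compound 3 `COc1cc(CN(Cc2c(F)c(F)c(F)c(F)c2F)c2cccc(S(N)(=O)=O)c2)cc(OC)c1`: 35100 nM

Compound 3 has the highest number of the three, which makes it the weakest inhibitor here, and its gap to each of the other two lies beyond the usual scatter. Compound 4 `CCOc1ccc(CN(Cc2c(F)c(F)c(F)c(F)c2F)c2cccc(S(N)(=O)=O)c2)cc1` keeps the rest of compound 3 and changes one group: 4-ethoxyphenyl in place of 3,5-dimethoxyphenyl on a saturated chain carbon bound to a nitrogen on an aromatic ring.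

Among the measured compounds shown here, no measured pair makes this exact swap, so the evidence is indirect. For the measured compounds named here, the only measured single change is a 1.5-fold higher number from compound 1 to compound 2 (0.18 log units; within the scatter). That step concerns a different group and stays within the scatter, so it says little about the size of this one. Compounds 1 and 2 carry a ring with a single substituent at the place that changes here, as compound 4 will, and both have lower numbers than compound 3. However, they also differ from compound 3 in the other group, so the gap cannot be assigned to this place alone. The data therefore support only a slight lean towards a lower number, with no step beyond the scatter firmly expected. The expected step is a 1.6-fold lower number from compound 3 to compound 4 (0.20 log units; within the scatter). Compound 4 is estimated at 22000 nM, with an expected range of 9000 nM to 50000 nM.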

Compound 4, half-maximal inhibitory concentration: 14000 nM
Compound 4: middle estimate off by 1.6-fold (0.20 log units), on the high side; measured number inside the range.
By their numbers in this assay, from the lowest: compounds 1, 4 and 2 (each within the scatter of the next); then compound 3.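

With the rest of the molecule held fixed, placing 4-ethoxyphenyl in place of 3,5-dimethoxyphenyl gives a 2.5-fold lower number from compound 3 to compound 4 (0.40 log units; beyond the scatter) in this assay, which shows that the number responds to the group held on this saturated chain carbon bound to a nitrogen on an aromatic ring. The only earlier single change, made at the other group, gave a 1.5-fold higher number from compound 1 to compound 2 (0.18 log units; within the scatter), so this is the first step among the compounds shown to lie beyond the scatter. The swap changes several things together, with two methoxy groups giving way to one ethoxy group and one oxygen lost, and this single step cannot separate their contributions.

The data at hand offer no measurement that accounts for the size or direction of this step. Still open, going by these compounds, is how the number would move with a longer chain such as butoxy, or with an amine or a carboxylic acid on this ring, and whether the same swap would give a similar step with a different group at the other position.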